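Halogen exchange from compound 1 to compound 3

A few compounds are considered here, and "the series" means these few. Any claim that something is new, unique, unknown or untested is made for them only; others in the source may bear on it.

- compound 1 `Cc1ccc(-c2cc(NC(=O)/C=C/c3ccc(Cl)cc3)n[nH]2)cc1`: 1520 nM
- compound 2 `O=C(/C=C/c1ccc(Cl)cc1)Nc1cc(-c2ccc(Br)cc2)[nH]n1`: 1080 nM

In a functional assay on B16-F10 cells (Mus musculus) for antiproliferative activity, read by MTT assay, with a stated time of 48 h (a lower number here means a stronger inhibitor, a higher number a weaker inhibitor), compound 1 gives 1520 nM and lies within the scatter of compound 2, so these two numbers set no order. Compound 3 `Cc1ccc(-c2cc(NC(=O)/C=C/c3ccc(Br)cc3)n[nH]2)cc1` keeps the core of compound 1 with one change: bromo in place of chloro on an aromatic carbon and this reads 4-chlorophenyl to 4-bromophenyl. Going by the values given here, one measured step bears on it: a 1.4-fold lower number from compound 1 to compound 2 (0.15 log units; within the scatter) also brings in bromo, but with methyl leaving and at another place on the molecule. Among the compounds with values here, no measured step exchanges chloro for bromo at this place, so the evidence is indirect. Within the data shown here, with a 1.4-fold lower number from compound 1 to compound 2 (0.15 log units; within the scatter) as the sole guide, no step beyond the scatter is expected in this assay and neither direction is favoured. The estimate means a 1.2-fold lower number from compound 1 to compound 3 (0.07 log units; within the scatter) as the expected step. For compound 3 the estimated value is 1300 nM with an expected range from 700 nM to 2400 nM in this read-out.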

Compound 3, half-maximal inhibitory concentration: 1570 nM
Compound 3: the middle estimate sits 1.2-fold (0.08 log units) below what was measured; the measured number falls inside the stated range.
By their numbers in this assay, from the lowest: compounds 2, 1 and 3 (each within the scatter of the next).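

In this assay, the direct exchange of chloro for bromo at this place gives a 1.0-fold higher number from compound 1 to compound 3 (0.01 log units; within the scatter), so within this pair the read-out does not separate the two halogens on this ring. The earlier comparison, a 1.4-fold lower number from compound 1 to compound 2 (0.15 log units; within the scatter), brought in bromo only at another place and with methyl leaving, so it could not isolate this exchange. No measurement shown accounts for the result.

The compounds shown leave open whether a group other than a halogen at this place, such as an amine, a methoxy group or a carboxylic acid, would give a step beyond the scatter. They also leave open how the core of compound 1 reads with bromo at both places.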